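From thione to methylsulfanyl on the saturated ring

A few compounds are considered here, and "the series" means these few. Any claim that something is new, unique, unknown or untested is made for them only; others in the source may bear on it.

Measured so far:
- compound 1 `O=C(CCCN1CCC(n2nnc3ccccc32)CC1)c1ccc(F)cc1`: "not determined" (no result reported)
- compound 2 `Cc1nc2ccccc2n1C1CCN(CCCC(c2ccc(F)cc2)c2ccc(F)cc2)CC1`: > 3 mg/kg
- compound 3 `Fc1ccc(C(CCCN2CCC(n3c(=S)[nH]c4ccccc43)CC2)c2ccc(F)cc2)cc1`: 1 mg/kg

The read-out is a functional assay on the whole organism (strain STD-ddY) with Mus musculus as the target, with stated times of 1 h and 24 h; on this read-out lower numbers stand for an effect already at smaller amounts and higher numbers for an effect only at larger amounts of compound. Compound 1 has no result in this assay, its entry reads "not determined" (no result reported). For compound 2 only a limit of the assay was reached, namely > 3 mg/kg. Among the measured compounds shown here, compound 3 is the one compound with a number here, giving 1 mg/kg in this assay. For the measured compounds named here, the single measured step is an at least 3.0-fold lower number from compound 2 to compound 3 (0.47 log units; beyond the scatter), and it leans on (the limit of > 3 mg/kg in this assay, at which 1 of the 3 values shown sits), a limit rather than a number, so its true size is open.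

The next compound is compound 4 `CSc1nc2ccccc2n1C1CCN(CCCC(c2ccc(F)cc2)c2ccc(F)cc2)CC1`. It differs from compound 3 by a group of 11 heavy atoms (8 carbon, 2 nitrogen, 1 sulfur; one five-membered aromatic ring with 2 hetero atoms, one six-membered aromatic ring of carbon only) in place of a group of 10 heavy atoms (7 carbon, 2 nitrogen, 1 sulfur; one five-membered aromatic ring with 2 hetero atoms, one six-membered aromatic ring of carbon only), on a saturated ring carbon. That is the same place that was altered in the step from compound 2 to compound 3, and compound 4 sits between the two: it keeps the sulfur of compound 3 yet carries a methyl as compound 2 does. Compound 4 is therefore expected to land between those two entries, closer to compound 3. The expected shift is a 2.0-fold higher number from compound 3 to compound 4 (0.30 log units; within the scatter), a small worsening that may stay within the scatter. Compound 4 is estimated at 2 mg/kg, with a range from 0.7 mg/kg to 6 mg/kg.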

Compound 4, dose for half-maximal effect: 2.4 mg/kg
Beside the measured number, compound 4's estimate is 1.2-fold (0.08 log units) below it; measured number inside the range.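

In this assay, among the compounds shown here, the first step at this place on the saturated ring that joins two real numbers is a 2.4-fold higher number from compound 3 to compound 4 (0.38 log units; beyond the scatter), whereas the earlier step from the methyl compound rested on a limit. It is a modest step beyond the scatter: the entering 2-(methylsulfanyl)-1H-benzimidazol-1-yl group has 0 hydrogen-bond donors where the leaving group has 1, so this place responds measurably even to a swap of nearly equal size. The direct comparison of methylsulfanyl with methyl on the aromatic carbon, an at least 1.2-fold lower number from compound 2 to compound 4 (0.09 log units; that floor lies within the scatter), has a floor within the scatter, so it does not yet show that the sulfur-linked group improves on methyl, and its true size stays open: the limit of > 3 mg/kg in this assay, at which 1 of the 4 values shown sits.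

The thione and methylsulfanyl groups differ in more than one respect at once, so these compounds cannot tell whether the added methyl or the lost hydrogen-bond donor goes with the higher number. As far as these compounds go, it also remains open how ethylsulfanyl or an amine in place of methylsulfanyl would read in this assay, which would show how far this place tolerates change.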